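The compounds below may be only part of what the source reports. "The series", "measured", "known", "first", "only" and "open" are said of these compounds alone.

Compound 1 `COc1ccc2c(=O)c(/C=C/C(=O)Nc3cccc(Cl)c3)coc2c1` and compound 2 `COc1ccc2c(=O)c(/C=C/C(=O)Nc3cc(C)ccc3C)coc2c1` share one core and differ only in the group attached to the amide-type nitrogen. In an ADME assay on HepG2 2.2.15 cells (Homo sapiens) for cytotoxicity, read by MTT assay, with stated times of 48 h and 9 days (on this read-out higher numbers stand for lower toxicity in this test and lower numbers for higher toxicity in this test), compound 1 gives 1100000 nM, and in the same test compound 2 gives 1100000 nM. The step of no change at the digits printed from compound 1 to compound 2 (within the scatter) shows nothing beyond the scatter, so compound 2 stands level with compound 1 on these numbers. Compound 3 `COc1ccc2c(=O)c(/C=C/C(=O)NCc3ccc(F)cc3)coc2c1` carries a further exchange at the same nitrogen: 4-fluorobenzyl in place of 2,5-dimethylphenyl on an amide-type nitrogen. Within the data shown here, the only measured step that bears on this position is the one just described, and it was flat. With one exchange at this nitrogen already leaving the read-out unmoved, the expected step for compound 3 is no change at the digits printed from compound 2 to compound 3 (within the scatter), that is, none beyond the scatter. Compound 3 is therefore estimated at 1100000 nM in this assay, with a range from 500000 nM to 2200000 nM.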

Compound 3, half-maximal cytotoxic concentration: 133000 nM
Estimate against measurement, compound 3: 8.3-fold (0.92 log units) above; measured number outside the range, below it.
By their numbers in this assay, from the lowest: compound 3; then compounds 1 and 2 (each within the scatter of the next).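

In this assay, the exchange for 4-fluorobenzyl gives an 8.3-fold lower number from compound 2 to compound 3 (0.92 log units; beyond the scatter), and the same group gives an 8.3-fold lower number from compound 1 to compound 3 (0.92 log units; beyond the scatter), so the group on this amide-type nitrogen can move the read-out after all, here towards higher toxicity in this test. The 3-chlorophenyl and 2,5-dimethylphenyl groups stand level, and only the 4-fluorobenzyl group stands apart, but a single compound cannot show whether the benzyl part or the fluorine carries the step. No measurement shown here accounts for this step.

A plain benzyl group, without fluorine, would be needed to separate those two parts. Going by these compounds, how a longer chain such as phenylethyl, or a small group such as ethyl, on this nitrogen would read also remains open.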